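The source may hold more compounds than are shown below. What is called first, only, known or untested is meant among the compounds shown, and "the series" means these compounds.

Compound 3 `Cc1ccc(OCC(=O)N(Cc2cccs2)c2ccon2)cc1` gives 2 nM in an assay on HEK293 cells for agonist activity at transient receptor potential cation channel subfamily M member 8 (Homo sapiens), read by fluorescence and calcium flux, with a stated time of 15 min (on this read-out higher numbers stand for an effect only at larger amounts of compound and lower numbers for an effect already at smaller amounts), the second highest of the three numbers measured; compound 2 `Cc1ccc(OCC(=O)N(Cc2cccs2)c2ccn[nH]2)cc1` gives 0.2 nM and compound 1 `Cc1ccc(OCC(=O)N(Cc2cccs2)C2CCCCC2)cc1` gives 40000 nM. Compound 4 `CCCN(Cc1cccs1)C(=O)COc1ccc(C)cc1` differs from compound 3 by propyl in place of 1,2-oxazol-3-yl on an amide-type nitrogen. The step that bears on this is the one in which a ring was put on the same nitrogen: a 20000-fold lower number from compound 1 to compound 3 (4.30 log units; beyond the scatter). Compound 4 carries no ring there, so a step of similar size in the opposite direction is expected, though a propyl chain is not cyclohexyl. The estimated step is a 10000-fold higher number from compound 3 to compound 4 (4.00 log units; beyond the scatter), giving compound 4 an expected value of 20000 nM, within a range of 2000 nM to 200000 nM.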

Compound 4, half-maximal effective concentration: 40 nM
Estimate against measurement, compound 4: 500-fold (2.70 log units) above, outside the stated range (below it).
By their numbers in this assay, from the lowest: compound 2; then compound 3; then compound 4; then compound 1.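

The propyl result shows that a low number in this assay does not need a ring on the amide-type nitrogen: with no ring there, the change gives a 1000-fold lower number from compound 1 to compound 4 (3.00 log units; beyond the scatter) overall. Even so, the five-membered aromatic rings keep the lowest numbers, as swapping 1,2-oxazol-3-yl for propyl gives a 20-fold higher number from compound 3 to compound 4 (1.30 log units; beyond the scatter) and swapping 1H-pyrazol-5-yl for propyl gives a 200-fold higher number from compound 2 to compound 4 (2.30 log units; beyond the scatter) on this nitrogen. No measurement offered here explains these differences.

Still open, on these data alone, is whether a longer chain such as butyl, or a small saturated ring such as cyclopropyl, would sit nearer propyl or cyclohexyl.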